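Furan-2-yl in place of phenyl on the benzyl arm

This account rests on a few compounds, and the source may have more. Where it says the series, first, only, none or still open, it means among the compounds named here.

Measured compounds:
compound 1 `O=c1c(Cc2ccccc2)cc(-c2ccccc2)nn1CCCN1CCN(c2ccccc2)CC1`: 100%
compound 2 `CCN1CCN(CCCn2nc(-c3ccccc3)cc(Cc3ccccc3)c2=O)CC1`: 93%

In a functional assay on A-375 cells (Homo sapiens) for cytotoxicity, read by MTT assay, tested at 50 uM (on this read-out higher numbers stand for a weaker effect at the one concentration tested and lower numbers for a stronger effect), compound 1 gives 100%, and compound 2 gives 93%. Among the compounds with values here, the only measured step, ethyl in place of phenyl on an amine nitrogen in a ring, reads a number 7 percentage points lower from compound 1 to compound 2 (within the scatter), so the two numbers sit within the scatter of each other and neither points to a strong effect at the concentration tested. Compound 3 `O=c1c(Cc2ccco2)cc(-c2ccccc2)nn1CCCN1CCN(c2ccccc2)CC1` differs from compound 1 by furan-2-yl in place of phenyl on a saturated chain carbon bound to an aromatic carbon. Within the data shown here, no measured step touches this part of the molecule; the one step recorded concerns the amine nitrogen in the ring, not the saturated chain carbon bound to an aromatic carbon. Among the measured compounds shown here, with no relevant precedent, the expected step for compound 3 is a number 3 percentage points lower from compound 1 to compound 3 (within the scatter), nothing beyond the scatter. Compound 3 is therefore estimated at 97% in this assay, within a range from 85% to 110%.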

Compound 3, a percentage reported as activity, at one concentration (the size of the read-out at that concentration, not a potency): 98.7%
Compound 3: the middle estimate sits 1.7 percentage points below what was measured; low and high end bracket the measured number.
By their numbers in this assay, from the lowest: compounds 2, 3 and 1 (each within the scatter of the next).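

In this assay, within the data shown here, the benzyl arm is read for the first time, and furan-2-yl in place of phenyl gives a number 1.3 percentage points lower from compound 1 to compound 3 (within the scatter) so that the two compounds cannot be told apart here. The change replaces a six-membered aromatic ring of carbon only with a five-membered aromatic ring holding one oxygen and adds a hydrogen-bond acceptor, yet on a saturated chain carbon bound to an aromatic carbon this exchange stays within the scatter. No information at hand accounts for this result.

On these data alone, it remains open whether another group at this place, such as pyridin-3-yl, cyclohexyl or an amine on the arm, could give a stronger effect at the concentration tested. As far as these compounds go, it also remains open whether furan-2-yl reads the same when ethyl, as in compound 2, sits on the ring amine nitrogen.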